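The compounds below may be only part of what the source reports. "The series", "measured", "known", "first", "only" and "open" are said of these compounds alone.

Compounds measured so far:
compound 1, `CCC(c1ccc(O)c(O)c1)c1ccc(O)c(OC)c1`, 90%;
compound 2, `CCC(c1ccc(O)c(OC)c1)c1cccc(O)c1O`, 90%.

In a functional assay for inhibition, with a stated time of 18 h, tested at 100 ug/mL (a higher number here means more inhibition at the concentration tested (going by the name of the read-out), a lower number less inhibition), compound 1 gives 90%, and compound 2 gives 90% in this assay; the two values agree at the digits shown, and the gap between them lies within the usual scatter, so neither can be placed above the other. Compound 2 is the nearest measured neighbour of the unmeasured compound 3, `CCOc1cccc(C(CC)c2ccc(O)c(OC)c2)c1O`. The difference between the two is ethyl in place of hydrogen on an oxygen on an aromatic ring; cut one bond further out it reads hydroxy to ethoxy. Among the compounds with values here, no measured pair shows this change, so its effect in this assay is not known from the data. Compound 3 is expected to give 72% in this assay, with a range from 40% to 95%. The step this estimate means, a number 18 percentage points lower from compound 2 to compound 3 (beyond the scatter), is expected to be a loss somewhat beyond the scatter, though a value close to that of compound 2 cannot be excluded.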

Compound 3, a percentage reported as inhibition, at one concentration (the size of the read-out at that concentration, not a potency): 89%
Estimate against measurement, compound 3: 17 percentage points below; measured number inside the range.
By their numbers in this assay, from the lowest: compounds 3, 1 and 2 (each within the scatter of the next).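

In this assay, within the data shown here, ethyl in place of hydrogen on an oxygen on an aromatic ring comes with a number 1 percentage points lower from compound 2 to compound 3 (within the scatter), the first measured pair to show this change. At this position, then, hydroxy can give way to ethoxy without a difference that this assay can resolve at the concentration tested, so the free hydroxy hydrogen at this place is not needed to keep the read-out at the level of compound 2. No supporting measurement bears on why the two compounds read alike.

The compounds shown leave open whether a longer chain on this oxygen, or a group such as an amine or a carboxylic acid at this place, would hold the read-out. Because each value comes from a single concentration, they also leave open whether compound 2 and compound 3 would match in potency.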